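The compounds below may be only part of what the source reports. "The series", "measured", "known", "first", "only" and "open" are said of these compounds alone.

Measured compounds:
Compound 1 `CN(C)c1ccc(C(=O)Nc2ccc(Oc3ncnc4ccsc34)cc2)cc1`: 20200 nM
Compound 2 `c1cc(N2CCCC2)nc(Nc2ccc(Oc3ncnc4ccsc34)cc2)n1`: "not active" (no number reported)
Compound 3 `CN(c1ccc(Oc2ncnc3sccc23)cc1)c1nccc(N2CCc3ccccc3C2)n1`: 6390 nM

The read-out throughout is a functional assay on A549 cells (Homo sapiens) for inhibition, read by MTT assay, with a stated time of 72 h; on this read-out lower numbers stand for stronger inhibition and higher numbers for weaker inhibition. For the measured compounds named here, compound 2 stands apart from the other two: in this assay it is reported only as not active, with no number, so it cannot be placed on the same scale as compound 1 or compound 3, and no step from it can be sized.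

Compound 4 `c1ccc2c(c1)CCN(c1ccnc(Nc3ccc(Oc4ncnc5ccsc45)cc3)n1)C2` is the next compound in the series. Its change from compound 2 is 1,2,3,4-tetrahydroisoquinolin-2-yl in place of pyrrolidin-1-yl on an aromatic carbon. The entering group is also present in compound 3, which in this assay gives 6390 nM, though compound 3 differs from compound 4 in other parts of the structure as well, so that value is only a loose guide.

Going by the values given here, with no measured step for this change, the expectation for compound 4 rests on compound 3 alone: a move from an inactive starting point toward a measurable number is expected, in the direction of lower values, with considerable uncertainty and a real chance of another limit-only result. The estimate for compound 4 in this assay is 15000 nM, within a range of 3000 nM to 60000 nM.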

Compound 4, half-maximal inhibitory concentration: 17000 nM
Compound 4: the middle estimate sits 1.1-fold (0.05 log units) below what was measured; the measured number falls inside the stated range.
By their numbers in this assay, from the lowest: compound 3; then compounds 4 and 1 (each within the scatter of the next).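

In this assay, for the compounds shown here, compound 4 gives 17000 nM while compound 2 has no number, so no step between compound 2 and compound 4 can be read. The compounds shown leave open what the exchange of pyrrolidin-1-yl for 1,2,3,4-tetrahydroisoquinolin-2-yl does on its own. No evidence bears on this result.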